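Cyclic and open-chain dihydroxyphenyl alkanes on MCF7 cells

The source may report more compounds than this note shows. Statements on the series, on what has been measured and on what is new or still open speak of the compounds shown alone.

Measured so far:
Compound 1 `Oc1cc2cc(c1)Oc1c(O)cc(cc1O)CCCCCCC/C=C/CCCCC2` gives 31800 nM in an ADME assay on MCF7 cells (Homo sapiens) for cytotoxicity; on this read-out lower numbers stand for stronger inhibition and higher numbers for weaker inhibition.
Compound 2 `COc1cc(O)cc(CCCCCCCCCCCCCCc2cc(O)cc(O)c2)c1` gives 29400 nM in this assay.
Compound 3 `Oc1cc2cc(c1)Oc1c(O)cc(cc1O)CCCCCCCCCCCCCC2` gives 32400 nM in this assay.

In this assay compound 2 has the smallest number of the three, yet its gaps to compound 1 and to compound 3 both lie within the scatter, so the three compounds cannot be told apart on these numbers.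

Compound 4 `Oc1cc(O)cc(CCCCCCCCCCCCCCc2cc(O)cc(O)c2)c1` has not been measured. It differs from compound 2 in one place hydrogen in place of methyl on an oxygen on an aromatic ring — methoxy to hydroxy, giving a 3,5-dihydroxyphenyl in place of the 3-hydroxy-5-methoxyphenyl. Within the data shown here, no measured pair shows this change, and the three measured compounds sit together regardless of their other differences. The step from compound 2 to compound 4 in this assay is therefore expected to be small, a 1.1-fold lower number from compound 2 to compound 4 (0.04 log units; within the scatter), not beyond the scatter. Compound 4 is estimated at 27000 nM, within 13000 nM to 55000 nM.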

Compound 4, half-maximal inhibitory concentration: 29200 nM
The estimate for compound 4 lay 1.1-fold (0.03 log units) below the measured number; the range from low to high includes it.
By their numbers in this assay, from the lowest: compounds 4, 2, 1 and 3 (each within the scatter of the next).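

In this assay, among these compounds, the change from methoxy to hydroxy gives a 1.0-fold lower number from compound 2 to compound 4 (0.00 log units; within the scatter), the first single-place step that can be read. At this position, on this open-chain compound, the methyl on the oxygen therefore makes no difference that can be read on this read-out. Nothing available bears on why the step is so small.

Still open, going by these compounds, is whether an amine in place of this hydroxy, or a longer chain linking the two aromatic rings, would move the number beyond the scatter.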